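Swapping the benzyl ring substituents on a benzimidazole acylurea

The source may report more compounds than this note shows. Statements on the series, on what has been measured and on what is new or still open speak of the compounds shown alone.

Two compounds share one core and differ only in the group on the benzyl ring. Compound 1 `Cc1ccc(NC(=O)NC(=O)c2ccc(OCc3ccc(C(F)(F)F)cc3)cc2)cc1-c1nc2ccccc2[nH]1` carries a trifluoromethyl there; in a functional assay on MGC-803 cells (Homo sapiens) for inhibition, read by MTT assay, with a stated time of 48 h (a higher number here means a weaker inhibitor, a lower number a stronger inhibitor), compound 1 gives 14900 nM. Among the measured compounds shown here, compound 2 `Cc1ccc(COc2ccc(C(=O)NC(=O)Nc3ccc(C)c(-c4nc5ccccc5[nH]4)c3)cc2)cc1` carries a methyl instead, and in this assay compound 2 gives 4250 nM, the lowest of the two numbers so far; the step of a 3.5-fold lower number from compound 1 to compound 2 (0.54 log units; beyond the scatter) was beyond the scatter. Compound 3 `Cc1ccc(NC(=O)NC(=O)c2ccc(OCc3ccc(Cl)cc3Cl)cc2)cc1-c1nc2ccccc2[nH]1` changes the same ring again: 2,4-dichlorophenyl in place of 4-methylphenyl on a saturated chain carbon bound to an oxygen on an aromatic ring. For the measured compounds named here, no measured step covers this exact exchange; the only step on record, from compound 1 to compound 2, shows that a change on this ring can move the number modestly. A modest rise from compound 2 is therefore expected, as a 1.6-fold higher number from compound 2 to compound 3 (0.22 log units; within the scatter). Compound 3 is estimated at 7000 nM in this assay, with a range from 2500 nM to 20000 nM.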

Compound 3, half-maximal inhibitory concentration: 2740 nM
Compound 3: the middle estimate sits 2.6-fold (0.41 log units) above what was measured; measured number inside the range.
By their numbers in this assay, from the lowest: compounds 3 and 2 (each within the scatter of the next); then compound 1.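

Putting 2,4-dichlorophenyl in place of 4-methylphenyl on this saturated chain carbon gives a 1.6-fold lower number from compound 2 to compound 3 (0.19 log units; within the scatter) in this assay, so the two rings cannot be told apart in this test, even though one carries two chlorines and the other a methyl. Against the trifluoromethyl ring, the same 2,4-dichlorophenyl gives a 5.4-fold lower number from compound 1 to compound 3 (0.74 log units; beyond the scatter), which means compound 1, with its 4-(trifluoromethyl)phenyl, now stands apart from two neighbours rather than one. No measurement on hand explains why these numbers differ.

On these data alone, how a single chlorine, as in 4-chlorophenyl, would compare with the two chlorines of compound 3 remains open. So does whether an amine or a carboxylic acid on this ring would keep the number in the same range or shift it.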